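The source may hold more compounds than are shown below. What is called first, only, known or untested is meant among the compounds shown, and "the series" means these compounds.

Compound 1 `CCCCSc1nsnc1[C@H]1CN2CCC[C@@H]1C2` gives 0.017 mg/kg in a functional assay on the whole organism for inhibition, with Rattus norvegicus as the target; a higher number here means that more compound is needed for the effect, a lower number that less compound is needed.
Compound 2 `CCSc1nsnc1C1CN2CCC[C@H]1C2` gives 0.045 mg/kg in this assay.
Compound 3 `CCCSc1nsnc1C1CN2CCC[C@H]1C2` gives 0.056 mg/kg in this assay.

Compound 3 carries the highest of the three numbers. Its nearest neighbour is compound 2, and the step of a 1.2-fold higher number from compound 2 to compound 3 (0.09 log units; within the scatter) lies within the scatter, so the two cannot be ordered. Among the compounds with values here, compound 1 stands furthest off, its number lower than that of compound 3 by a margin beyond the scatter, but these two differ in more than one place and no single step joins them.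

Compound 4 `CCCSc1nsnc1[C@H]1CN2CCC[C@@H]1C2` keeps every atom and bond of compound 3; the difference is the two compounds have the same atoms and bonds; at least one stereo element is drawn with a configuration in one of them and without one in the other: 2 of 3 stereo elements differ; a stereocentre at a saturated ring carbon is drawn without a configuration in compound 3 and R in compound 4; a stereocentre at a saturated ring carbon is drawn R in compound 3 and S in compound 4. Within the data shown here, no measured step alters a stereocentre alone, so nothing directly bears on this change. Among the measured compounds shown here, the only step available, from compound 2 to compound 3, concerns the chain and is within the scatter, which says nothing about stereochemistry. What the values do show is that compound 1, whose stereocentres are drawn as in compound 4, has the lowest number of the three. Compound 4 is therefore expected to reach a somewhat lower number than compound 3, a step of a 2.0-fold lower number from compound 3 to compound 4 (0.30 log units; within the scatter), though with wide uncertainty. The estimate for compound 4 is 0.028 mg/kg, ranging from 0.012 mg/kg to 0.07 mg/kg.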

Compound 4, dose for half-maximal effect: 0.013 mg/kg
Beside the measured number, compound 4's estimate is 2.2-fold (0.33 log units) above it, and the stated range covers the measured number.
By their numbers in this assay, from the lowest: compounds 4 and 1 (each within the scatter of the next); then compounds 2 and 3 (each within the scatter of the next).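

In this assay, within the data shown here, the stereocentres now prove to matter, which no earlier step could show: with atoms and bonds unchanged, the change in drawn configuration gives a 4.3-fold lower number from compound 3 to compound 4 (0.63 log units; beyond the scatter). The size of that step needs caution, for one reason: the fact that one of compounds 3 and 4 is drawn with a defined configuration and the other without, at the place where they differ. Placing hydrogen in place of methyl on the chain of the fully defined form gives a 1.3-fold lower number from compound 1 to compound 4 (0.12 log units; within the scatter), so the chain change can be resolved on neither form, and the two steps agree: the same change on two cores in this assay, a 1.2-fold higher number (0.09 log units; within the scatter) from compound 2 to compound 3 and a 1.3-fold higher number (0.12 log units; within the scatter) from compound 4 to compound 1, 1.1-fold (0.02 log units) apart, within the scatter of two such steps.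

What remains open is how each stereocentre acts alone, since no pair shown alters just one of them, and where the other fully defined stereoisomers would stand. Also open, going by these compounds, is whether a hexyl chain on the sulfur, or an oxygen in place of that sulfur, would leave the number in this assay close to those of compound 1 and compound 4.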